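Swapping methyl for trifluoromethyl on the benzyl arm

The source may report more compounds than this note shows. Statements on the series, on what has been measured and on what is new or still open speak of the compounds shown alone.

Compound 1 `Cc1cc(S(=O)(=O)/N=C(\N)n2nccc2-c2ccccc2)c(SCc2ccc(C(F)(F)F)cc2)cc1Cl`: 25000 nM
Compound 2 `Cc1cc(S(=O)(=O)/N=C(\N)n2nccc2-c2ccccc2)c(SCc2cccc3ccccc23)cc1Cl`: 58000 nM
Compound 3 `Cc1cc(S(=O)(=O)/N=C(\N)n2nccc2-c2ccccc2)c(SCc2ccccc2C)cc1Cl`: 23000 nM

Three compounds sharing one core were tested in a functional assay on MCF7 cells (Homo sapiens) for cytotoxicity, read by MTT assay, with a stated time of 72 h; a higher number here means a weaker inhibitor, a lower number a stronger inhibitor. Compound 3 gives the lowest number of the three, yet its gap to compound 1 is small: a 1.1-fold lower number from compound 1 to compound 3 (0.04 log units; within the scatter). Only compound 2 stands apart, with a 2.5-fold lower number from compound 2 to compound 3 (0.40 log units; beyond the scatter) and a 2.3-fold higher number from compound 1 to compound 2 (0.37 log units; beyond the scatter).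

Compound 4 `Cc1cc(S(=O)(=O)/N=C(\N)n2nccc2-c2ccccc2)c(SCc2ccccc2C(F)(F)F)cc1Cl` carries one change from compound 3: trifluoromethyl in place of methyl on an aromatic carbon. The closest comparison among measured steps is that from compound 1 to compound 3, where a 4-(trifluoromethyl)phenyl and a 2-methylphenyl give numbers within the scatter of each other. Nothing measured here isolates trifluoromethyl against methyl at the same aromatic carbon, so the expectation rests on that near-equivalence. Compound 4 is therefore expected to show no step beyond the scatter, a 1.1-fold higher number from compound 3 to compound 4 (0.04 log units; within the scatter). In this assay compound 4 is estimated at 25000 nM, with a range from 12000 nM to 50000 nM.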

Compound 4, half-maximal inhibitory concentration: 21000 nM
Estimate against measurement, compound 4: 1.2-fold (0.08 log units) above, within the range that was stated.
By their numbers in this assay, from the lowest: compounds 4, 3 and 1 (each within the scatter of the next); then compound 2.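

In this assay, the exchange of methyl for trifluoromethyl is now seen directly on this aromatic carbon, ortho to a large group, and it gives a 1.1-fold lower number from compound 3 to compound 4 (0.04 log units; within the scatter), so the larger group leaves the number unchanged within the scatter. Among these compounds, the pair of compounds 1 and 4 adds a comparison the earlier compounds did not offer, the 2-(trifluoromethyl)phenyl against the 4-(trifluoromethyl)phenyl, and a 1.2-fold lower number from compound 1 to compound 4 (0.08 log units; within the scatter) shows no separation between them either. The naphthalen-1-yl arm remains the one that stands apart, now also against the new compound, with a 2.8-fold lower number from compound 2 to compound 4 (0.44 log units; beyond the scatter).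

No measurement in what is shown offers a reason for any of these steps. As far as these compounds go, whether an amine or a carboxylic acid on this same aromatic carbon would move the number beyond the scatter remains open.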